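The source may hold more compounds than are shown below. What is called first, only, known or untested is meant among the compounds shown, and "the series" means these compounds.

In a functional assay on MCF7 cells (Homo sapiens) for inhibition, read by MTT assay, with a stated time of 72 h (on this read-out higher numbers stand for weaker inhibition and lower numbers for stronger inhibition), three compounds sharing one core have been measured. Compound 1 `CC(C)c1ccc(-c2nc(SCc3cn(CC(=O)NC(=O)Nc4ccccn4)nn3)nc(Nc3cccc(C(F)(F)F)c3)c2C#N)cc1` gives 8620 nM. Compound 2 `CC(C)c1ccc(-c2nc(SCc3cn(CC(=O)NC(=O)Nc4ccccn4)nn3)nc(Nc3ccccc3F)c2C#N)cc1` reaches only the limit of the assay, > 64000 nM. Compound 3 `Cc1ccc(Nc2nc(SCc3cn(CC(=O)NC(=O)Nc4ccccn4)nn3)nc(-c3ccc(C(C)C)cc3)c2C#N)cc1` likewise reaches only the limit, > 64000 nM. Compound 3 therefore stands at the weak end of what has been measured: the step of an at least 7.4-fold higher number from compound 1 to compound 3 (0.87 log units; beyond the scatter) lies beyond the scatter, while the step that the two limits leave unreadable from compound 2 to compound 3 cannot be read from two limits.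

Compound 4 `COc1ccccc1Nc1nc(SCc2cn(CC(=O)NC(=O)Nc3ccccn3)nn2)nc(-c2ccc(C(C)C)cc2)c1C#N` differs from compound 3 by 2-methoxyphenyl in place of 4-methylphenyl on a nitrogen on an aromatic ring. Within the data shown here, two measured steps bear on a change of this aryl group on the nitrogen: an at least 7.4-fold higher number from compound 1 to compound 2 (0.87 log units; beyond the scatter) and an at least 7.4-fold higher number from compound 1 to compound 3 (0.87 log units; beyond the scatter), both at least modest moves toward the limit. Among the measured compounds shown here, no measured step shows a move away from the limit, and compound 2, carrying another group on the same nitrogen, also sits there (the limit of > 64000 nM in this assay, at which 2 of the 3 values shown sit).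

The step that the limit leaves unreadable from compound 3 to compound 4 is therefore expected to be small or not readable. Compound 4 is expected to stay at or near the limit, with an estimate of 70000 nM and a range from 20000 nM to 200000 nM, the most likely outcome being another limit rather than a number.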

Compound 4, half-maximal inhibitory concentration: 19300 nM
For compound 4 the middle estimate is 3.6-fold (0.56 log units) above the measured one, outside the stated range (below it).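

In this assay, the aryl group on the nitrogen now shows a move away from the limit, which no earlier step had shown: 2-methoxyphenyl in place of 4-methylphenyl gives an at least 3.3-fold lower number from compound 3 to compound 4 (0.52 log units; beyond the scatter), and methoxy in place of fluoro on an aromatic carbon gives an at least 3.3-fold lower number from compound 2 to compound 4 (0.52 log units; beyond the scatter). Neither step has an exact size, because the values of compound 2 and compound 3 are limits and not numbers: the limit of > 64000 nM in this assay, at which 2 of the 4 values shown sit A measurable value at this position is therefore not confined to the 3-(trifluoromethyl)phenyl group, although that group still gives the lower number, with a 2.2-fold higher number from compound 1 to compound 4 (0.35 log units; beyond the scatter).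

The compounds shown leave open whether the gain belongs to the methoxy group itself or to where it sits on the ring, since 4-methylphenyl and 2-methoxyphenyl differ in both. They also leave open whether an ethoxy group or an amine in place of the methoxy would hold, improve or lose this value, and whether the change would read the same with the rest of the core altered.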